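A few compounds are considered here, and "the series" means these few. Any claim that something is new, unique, unknown or untested is made for them only; others in the source may bear on it.

The measured compounds:
compound 1, `O=C(c1ccc2c(c1)ncn2-c1ccccc1)N1CCCCC1`, 22 nM
compound 2, `Cc1ccc(-n2cnc3cc(C(=O)N4CCCCC4)ccc32)cc1`, 19 nM
compound 3, `O=C(c1ccc2c(c1)ncn2-c1ccc(C(F)(F)F)cc1)N1CCCCC1`, 86 nM

All three were tested in an assay on isolated protein for inhibition of 15-hydroxyprostaglandin dehydrogenase [NAD(+)] (Homo sapiens), read by fluorescence, with a stated time of 15 min; a lower number here means a stronger inhibitor, a higher number a weaker inhibitor. Compound 2 gives the lowest of the three numbers, though compound 1 lies within the scatter of it: a 1.2-fold lower number from compound 1 to compound 2 (0.06 log units; within the scatter). Compound 3 stands further off: a 4.5-fold higher number from compound 2 to compound 3 (0.66 log units; beyond the scatter), and from the unsubstituted parent a 3.9-fold higher number from compound 1 to compound 3 (0.59 log units; beyond the scatter). These two steps are the only ones beyond the scatter, and both concern the group carried on the phenyl ring attached to the aromatic nitrogen of the shared core.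

Compound 4, `CCCCn1cnc2cc(C(=O)N3CCCCC3)ccc21`, has not yet been measured in this assay. It differs from compound 2 as follows: butyl in place of 4-methylphenyl on an aromatic nitrogen. The aromatic ring leaves altogether and a butyl chain enters in its place. For the measured compounds named here, none of the measured steps covers such a change; they vary only the substituent on that ring, and they show that this region can shift the number, as compound 3 did, without saying which way a chain would go. The writer treats the loss of the ring as a larger departure than any measured step and expects a somewhat weaker inhibitor, with wide uncertainty. Compound 4 is expected to give 60 nM in this assay, within a range of 15 nM to 300 nM. That estimate means a step of a 3.2-fold higher number from compound 2 to compound 4 (0.50 log units; beyond the scatter).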

Compound 4, half-maximal inhibitory concentration: 68 nM
Estimate against measurement, compound 4: 1.1-fold (0.05 log units) below; the range from low to high includes it.
By their numbers in this assay, from the lowest: compounds 2 and 1 (each within the scatter of the next); then compounds 4 and 3 (each within the scatter of the next).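

In this assay the aromatic ring on the aromatic nitrogen proves not to be essential for inhibition, since compound 4 still gives 68 nM with butyl in its place. The exchange has a modest cost, seen in a 3.6-fold higher number from compound 2 to compound 4 (0.55 log units; beyond the scatter) and in a 3.1-fold higher number from compound 1 to compound 4 (0.49 log units; beyond the scatter) as well, so a chain at this position does not match the unsubstituted phenyl or the 4-methylphenyl group. Replacing the ring altogether puts compound 4 within the scatter of compound 3, which keeps the ring and carries trifluoromethyl on it, so the two changes reach the same range of numbers, and no measurement at hand accounts for either shift.

As far as these compounds go, whether a shorter chain such as ethyl, a longer chain such as octyl, or a saturated ring such as cyclohexyl would come closer to compound 2 remains open, as does the effect of benzyl, which sets a carbon between this nitrogen and a phenyl ring. Also unresolved is how a butyl chain ending in an amine or a carboxylic acid would fare at this nitrogen.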